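The source may report more compounds than this note shows. Statements on the series, on what has been measured and on what is new or still open speak of the compounds shown alone.

Measured so far in a functional assay on PC-12 cells (Rattus norvegicus) for cytotoxicity, read by MTT assay, with stated times of 3 h and 2 h, tested at 50 uM; on this read-out lower numbers stand for a weaker effect and higher numbers for a stronger effect at the one concentration tested:
compound 1 `O=C(CCCCC1CCSS1)NCc1cn(CCCCOc2ccc3ccc(=O)oc3c2)nn1` gives 75.8%
compound 2 `O=C(CCCCC1CCSS1)NCc1cn(CCCCOc2ccc3cc(-c4ccccc4)c(=O)oc3c2)nn1` gives 20.5%
compound 3 `O=C(CCCCC1CCSS1)NCc1cn(CCCCOc2ccc3cc(-c4ccc(Br)cc4)c(=O)oc3c2)nn1` gives 47.6%

In this assay compound 3 stands second highest of the three numbers: the step of a number 28.2 percentage points lower from compound 1 to compound 3 (beyond the scatter) separates it from compound 1, and the step of a number 27.1 percentage points higher from compound 2 to compound 3 (beyond the scatter) from compound 2.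

Compound 4 `O=C(CCCCC1CCSS1)NCc1cn(CCCCOc2ccc3cc(-c4ccc(Cl)c(Cl)c4)c(=O)oc3c2)nn1` differs from compound 3 in one place: 3,4-dichlorophenyl in place of 4-bromophenyl on an aromatic carbon. The step of a number 27.1 percentage points higher from compound 2 to compound 3 (beyond the scatter) is the one that bears most directly on this, since there too bromo in place of hydrogen on an aromatic carbon raised the number. The steps of a number 55.3 percentage points lower from compound 1 to compound 2 (beyond the scatter) and a number 28.2 percentage points lower from compound 1 to compound 3 (beyond the scatter) show that the aryl group itself lowers it. Compound 4 keeps a halogenated aryl group, so a small change is expected, a number 4.4 percentage points higher from compound 3 to compound 4 (within the scatter). Compound 4 is therefore estimated at 52%, in a range from 30% to 74%.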

Compound 4, a percentage reported as activity, at one concentration (the size of the read-out at that concentration, not a potency): 69.5%
Estimate against measurement, compound 4: 17.5 percentage points below; low and high end bracket the measured number.
By their numbers in this assay, from the lowest: compound 2; then compound 3; then compounds 4 and 1 (each within the scatter of the next).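

In this assay, within the data shown here, the halogens on the aryl ring at this position count for more than the earlier compounds showed: 3,4-dichlorophenyl in place of 4-bromophenyl gives a number 21.9 percentage points higher from compound 3 to compound 4 (beyond the scatter) and, in place of plain phenyl, a number 49 percentage points higher from compound 2 to compound 4 (beyond the scatter) on the same scale. Set against the hydrogen of the parent, it gives a number 6.3 percentage points lower from compound 1 to compound 4 (within the scatter) so an aryl group here need not lower the number, as phenyl and 4-bromophenyl did. No measurement at hand explains these differences. The compounds shown leave open whether one chlorine on the phenyl ring would serve as well as two. They also leave open how a phenyl ring carrying an amine or a carboxylic acid would behave here.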